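A few compounds are considered here, and "the series" means these few. Any claim that something is new, unique, unknown or untested is made for them only; others in the source may bear on it.

Measured so far in an ADME assay on HEK-293T cells (Homo sapiens) for cytotoxicity, read by MTT assay, with a stated time of 24 h (a lower number here means that less compound is tolerated, a higher number that more compound is tolerated), are two compounds:
- compound 1 `Cc1ccc(C)c(S(=O)(=O)n2c(-c3cn(-c4ccccc4)nc3-c3ccc(F)cc3)nc3ccccc32)c1` at 54200 nM
- compound 2 `O=S(=O)(c1ccc(Cl)cc1)n1c(-c2cn(-c3ccccc3)nc2-c2ccc(F)cc2)nc2ccccc21` at 93100 nM

Compound 2 at 93100 nM stands within the scatter of compound 1, so the two cannot be ranked. Next is compound 3 `O=S(=O)(c1ccc(C(F)(F)F)cc1)n1c(-c2cn(-c3ccccc3)nc2-c2ccc(F)cc2)nc2ccccc21`, with trifluoromethyl in place of chloro on an aromatic carbon, para to a large group (trifluoromethyl in place of chloro on an aromatic carbon). Among the measured compounds shown here, the only measured step (a 1.7-fold higher number from compound 1 to compound 2 (0.23 log units; within the scatter)) also changes the group on the sulfonyl sulfur, and it stayed within the scatter. No step beyond the scatter is therefore expected in this assay for this change, in either direction. The expected step is a 1.2-fold lower number from compound 2 to compound 3 (0.07 log units; within the scatter) as estimated. For compound 3 the estimated value is 80000 nM (range 35000 nM to 180000 nM).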

Compound 3, half-maximal cytotoxic concentration: 241000 nM
Estimate against measurement, compound 3: 3.0-fold (0.48 log units) below; measured number above the stated range.
By their numbers in this assay, from the lowest: compounds 1 and 2 (each within the scatter of the next); then compound 3.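

In this assay, trifluoromethyl in place of chloro on an aromatic carbon, para to a large group, gives a 2.6-fold higher number from compound 2 to compound 3 (0.41 log units; beyond the scatter) and so moves the number beyond the scatter, and 4-(trifluoromethyl)phenyl in place of 2,5-dimethylphenyl on the sulfonyl sulfur gives a 4.4-fold higher number from compound 1 to compound 3 (0.65 log units; beyond the scatter) as a further such step. This group on the sulfonyl sulfur can therefore separate compounds in this assay, which the step between compound 1 and compound 2 did not show. No available measurement explains this change.

Open, on these data alone, is whether an amine or a carboxylic acid at this place would also shift the number. Also open, as far as these compounds go, is whether the step holds when the rest of the core differs.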